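The source may hold more compounds than are shown below. What is called first, only, known or untested is meant among the compounds shown, and "the series" means these compounds.

Of the compounds shown here, three built on one shared core have been measured in a functional assay on DU-145 cells (Homo sapiens) for inhibition, read by trypan blue exclusion, with a stated time of 72 h; a higher number here means a weaker inhibitor, a lower number a stronger inhibitor. Compound 1 (`Cn1c(=O)c(S(=O)(=O)c2ccc(F)cc2F)cc2cnc(Nc3cccc4[nH]ccc34)nc21`) gives 750 nM, and compound 2 (`COc1ccc(Nc2ncc3cc(S(=O)(=O)c4ccc(Cl)cc4)c(=O)n(C)c3n2)cc1`) gives 30000 nM. Compound 3 (`Cn1c(=O)c(S(=O)(=O)c2ccc(Cl)cc2)cc2cnc(Nc3cccc4[nH]ccc34)nc21`) gives 5000 nM, the second highest number of the three and clearly separated from both neighbours. Compound 4 (`Cn1c(=O)c(S(=O)(=O)c2ccc(Cl)cc2)cc2cnc(Nc3cnc4ccccc4c3)nc21`) keeps the 4-chlorophenyl of compound 3 and changes only the group on a nitrogen on an aromatic ring, with quinolin-3-yl in place of 1H-indol-4-yl on a nitrogen on an aromatic ring.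

Two measured steps are available. The first, a 6.7-fold higher number from compound 1 to compound 3 (0.82 log units; beyond the scatter), is modest and beyond the scatter, but it concerns the group on a sulfonyl sulfur, so it says little about this change. The second, a 6.0-fold lower number from compound 2 to compound 3 (0.78 log units; beyond the scatter), is also modest and beyond the scatter, and it comes at the same nitrogen, with 1H-indol-4-yl in place of 4-methoxyphenyl. For the measured compounds named here, this single case is the only guide: the one compound without 1H-indol-4-yl at that nitrogen, compound 2, stands at 30000 nM. A modest rise in this assay is therefore expected, smaller than that step and with wide uncertainty. The expected change is a 2.4-fold higher number from compound 3 to compound 4 (0.38 log units; beyond the scatter). For compound 4 the estimated value is 12000 nM, with an expected range of 3000 nM to 40000 nM.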

Compound 4, half-maximal inhibitory concentration: 15000 nM
Compound 4: middle estimate off by 1.3-fold (0.10 log units), on the low side, within the range that was stated.
By their numbers in this assay, from the lowest: compound 1; then compound 3; then compounds 4 and 2 (each within the scatter of the next).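

In this assay, the step to quinolin-3-yl, a 3.0-fold higher number from compound 3 to compound 4 (0.48 log units; beyond the scatter), lies beyond the scatter, so 1H-indol-4-yl now has the lower number against two different groups on this nitrogen rather than one. The other new step, a 2.0-fold lower number from compound 2 to compound 4 (0.30 log units; within the scatter), lies within the scatter, so quinolin-3-yl and 4-methoxyphenyl cannot be told apart here, even though they differ in their counted atoms and rings; among the three compounds carrying 4-chlorophenyl, compounds 2, 3 and 4, none goes against the lead of 1H-indol-4-yl. The swap from compound 3 to compound 4 also trades a hydrogen-bond donor for a hydrogen-bond acceptor, but no measurement at hand explains the rise or links it to that difference.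

On these data alone, it remains open whether the lead of 1H-indol-4-yl carries over to the 2,4-difluorophenyl series, since compound 1 has no partner here that differs from it only at this nitrogen. As far as these compounds go, how a plain phenyl, a piperidine or an open-chain amine would read on this nitrogen also remains open.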